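The source may hold more compounds than are shown below. What is called first, only, known or untested is meant among the compounds shown, and "the series" means these compounds.

In a physicochemical assay for lipophilicity, read by HPLC, at pH 7.5 (a higher number here means a more lipophilic compound, a lower number a more polar compound), compound 1 (`CC[C@@H](Nc1c(C#N)c(-c2ccc(-c3cccc(C)c3)cc2)nc2cnccc12)C(N)=O`) gives 3. Within the data shown here, compound 2 (`CC[C@@H](Nc1c(C#N)c(-c2ccc(-c3cccnc3C)cc2)nc2cnccc12)C(N)=O`) gives 1.9, the lower of the two numbers so far.

The next change leads to compound 3 (`CC[C@@H](Nc1c(C#N)c(-c2ccc(-c3ccccc3Cl)cc2)nc2cnccc12)C(N)=O`), with 2-chlorophenyl in place of 2-methylpyridin-3-yl on an aromatic carbon, para to a large group: 2-chlorophenyl in place of 2-methylpyridin-3-yl on an aromatic carbon.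

Among the measured compounds shown here, one measured step bears on this change: a number 1.10 log units lower from compound 1 to compound 2 (beyond the scatter), with 2-methylpyridin-3-yl in place of 3-methylphenyl. It is a large step and the same ring leaves here, but the ring that enters is a different one of carbon only. For the measured compounds named here, no chlorine-bearing compound has been measured, so the read-across rests on a single pair and the range has to stay wide.

A large upward step in this assay is therefore expected, similar in size to the measured one but in the opposite direction. The estimated step is a number 1.10 log units higher from compound 2 to compound 3 (beyond the scatter). For compound 3, the expected value is 3, with an estimated range from 2.6 to 3.4.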

Compound 3, distribution coefficient: 2.9
Beside the measured number, compound 3's estimate is 0.10 log units above it, within the range that was stated.
By their numbers in this assay, from the lowest: compound 2; then compounds 3 and 1 (each within the scatter of the next).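

In this assay, 2-chlorophenyl in place of 2-methylpyridin-3-yl gives a number 1.00 log units higher from compound 2 to compound 3 (beyond the scatter), so a second ring of carbon only now stands apart from the ring with a hetero atom at this place, para to a large group. Compared directly, the two rings of carbon only do not separate, with 2-chlorophenyl in place of 3-methylphenyl giving a number 0.10 log units lower from compound 1 to compound 3 (within the scatter), so among the three compounds a chlorine and a methyl group on different ring carbons read alike, and only compound 2, the one compound with a ring nitrogen in this group, stands apart. No measurement shown accounts for the size of these steps, so the shift remains an observation without an explanation.

As far as these compounds go, the step from compound 2 to compound 3 exchanges the ring nitrogen and the methyl group for a chlorine in one move, so the share of each remains open, and 2-methylphenyl at this place would separate them. Also open, from the compounds shown here alone, is how far the reading moves with a charged group on this ring, such as a carboxylic acid or a dimethylamino group.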